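Phenyl to isopropyl on the amide substituent of compound 3

The source may hold more compounds than are shown below. What is called first, only, known or untested is meant among the compounds shown, and "the series" means these compounds.

Of the compounds shown here, three sharing one core have been measured in an assay on HEK293 cells for agonist activity at Toll-like receptor 2 (Homo sapiens); a higher number here means that more compound is needed for the effect, a lower number that less compound is needed. Compound 1 `CCCCCCCCCCCC(=O)OC[C@H](CSC[C@@H](N)C(=O)NCCO)OC(=O)CCCCCCCCCCC` gives 24 nM. Compound 2 `CCCCCCCCCCCC(=O)OC[C@H](CSC[C@@H](N)C(=O)NCCOCCOS(=O)(=O)O)OC(=O)CCCCCCCCCCC` gives 61 nM, and compound 3 `CCCCCCCCCCCC(=O)OC[C@H](CSC[C@@H](N)C(=O)NC(C)CCc1ccccc1)OC(=O)CCCCCCCCCCC` gives 160 nM. Compound 3 thus stands with the highest number of the three: a 6.7-fold higher number from compound 1 to compound 3 (0.82 log units; beyond the scatter) and a 2.6-fold higher number from compound 2 to compound 3 (0.42 log units; beyond the scatter), both beyond the scatter.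

Compound 4 `CCCCCCCCCCCC(=O)OC[C@H](CSC[C@@H](N)C(=O)NC(C)CCC(C)C)OC(=O)CCCCCCCCCCC` differs from compound 3 in one place: isopropyl in place of phenyl on a saturated chain carbon, three bonds along the chain from an amide-type nitrogen. Within the data shown here, no measured step exchanges one group for another at this position; the steps that exist change the whole substituent on the amide-type nitrogen, and they were modest in size, a 6.7-fold higher number from compound 1 to compound 3 (0.82 log units; beyond the scatter) and a 2.6-fold higher number from compound 2 to compound 3 (0.42 log units; beyond the scatter). They show that this part of the molecule shifts the read-out by modest amounts, without pointing to a direction for exchanging a phenyl for an isopropyl. Compound 4 is therefore expected to stay near compound 3, with a step of a 1.3-fold higher number from compound 3 to compound 4 (0.10 log units; within the scatter) that may well fall within the scatter. The estimate for compound 4 in this assay is 200 nM, with a range from 70 nM to 600 nM.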

Compound 4, half-maximal effective concentration: 190 nM
Compound 4: middle estimate off by 1.1-fold (0.02 log units), on the high side, within the range that was stated.
By their numbers in this assay, from the lowest: compound 1; then compound 2; then compounds 3 and 4 (each within the scatter of the next).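

In this assay, isopropyl in place of phenyl on a saturated chain carbon, three bonds along the chain from an amide-type nitrogen, gives a 1.2-fold higher number from compound 3 to compound 4 (0.07 log units; within the scatter) and stays within the scatter, so among these two compounds the six-membered aromatic ring is not needed to keep the read-out at this level. The larger differences still come from replacing the whole substituent on the amide-type nitrogen, with a 3.1-fold higher number from compound 2 to compound 4 (0.49 log units; beyond the scatter) and a 7.9-fold higher number from compound 1 to compound 4 (0.90 log units; beyond the scatter) both beyond the scatter and running the same way as the steps to compound 3, which places compounds 3 and 4 together above compounds 1 and 2. Nothing available explains why the two chain ends give such similar numbers.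

The compounds shown leave open whether this place accepts other kinds of group as readily, such as an amine, a carboxylic acid or a longer chain in place of the isopropyl. They also leave open whether a hydroxyl at the end of the 1,4-dimethylpentyl chain would bring the number closer to that of compound 1.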